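Defined configuration on the chloro analogue

The source may hold more compounds than are shown below. What is called first, only, known or untested is meant among the compounds shown, and "the series" means these compounds.

Compound 3 `O=C(NC1CCCC(NC(=O)c2ccccn2)C1)c1cccc(Cl)c1` gives 314 nM in a functional assay on HEK293 cells for antagonist activity at metabotropic glutamate receptor 5 (Homo sapiens), read by FLIPR and calcium flux; a lower number here means a stronger inhibitor, a higher number a weaker inhibitor; its number sits between those of compound 2 `N#Cc1cccc(C(=O)N[C@@H]2CCC[C@@H](NC(=O)c3ccccn3)C2)c1` at 231 nM and compound 1 `N#Cc1cccc(C(=O)NC2CCCC(NC(=O)c3ccccn3)C2)c1` at 531 nM, within the scatter of both. Compound 4 `O=C(N[C@@H]1CCC[C@@H](NC(=O)c2ccccn2)C1)c1cccc(Cl)c1` differs from compound 3 in that (the two compounds have the same atoms and bonds; at least one stereo element is drawn with a configuration in one of them and without one in the other: 2 of 2 stereo elements differ; a stereocentre at a saturated ring carbon is drawn without a configuration in compound 3 and R in compound 4; a stereocentre at a saturated ring carbon is drawn without a configuration in compound 3 and R in compound 4). Among the measured compounds shown here, the one measured step that bears on this change is a 2.3-fold lower number from compound 1 to compound 2 (0.36 log units; beyond the scatter), where the sole difference is the same drawing of configuration at the two ring carbons, as the fact that one of compounds 1 and 2 is drawn with a defined configuration and the other without, at the place where they differ records. The other measured step, a 1.7-fold lower number from compound 1 to compound 3 (0.23 log units; within the scatter), concerns chloro in place of cyano and is not repeated here, so it informs only the starting point. A step of similar size and in the same direction is therefore expected, with the caution that it rests on a single pair. For compound 4 the number in this assay is estimated at 145 nM, within a range from 70 nM to 320 nM. That estimate corresponds to an expected step of a 2.2-fold lower number from compound 3 to compound 4 (0.34 log units; beyond the scatter).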

Compound 4, half-maximal inhibitory concentration: 62 nM
Estimate against measurement, compound 4: 2.3-fold (0.37 log units) above, outside the stated range (below it).
By their numbers in this assay, from the lowest: compound 4; then compounds 2, 3 and 1 (each within the scatter of the next, the first and the last beyond it).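

Notes on the defined configuration: in this assay, the chloro pair gives a 5.1-fold lower number from compound 3 to compound 4 (0.70 log units; beyond the scatter), so the lower number seen with the cyano pair, a 2.3-fold lower number from compound 1 to compound 2 (0.36 log units; beyond the scatter), recurs with a second aromatic substituent. Chloro in place of cyano now gives a step beyond the scatter on the compounds with defined configuration, a 3.7-fold lower number from compound 2 to compound 4 (0.57 log units; beyond the scatter), whereas the same change stayed within the scatter without it. The two steps still cannot be told apart: the same change on two cores in this assay, a 1.7-fold lower number (0.23 log units; within the scatter) from compound 1 to compound 3 and a 3.7-fold lower number (0.57 log units; beyond the scatter) from compound 2 to compound 4, 2.2-fold (0.34 log units) apart, within the scatter of two such steps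

Still open, on these data alone, is how compounds with one or both of these ring carbons drawn S would read. Also open, as far as these compounds go, is whether fluoro, methoxy or trifluoromethyl in place of chloro on the aromatic carbon would give a lower or higher number than compound 4 with the same drawn configuration.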